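The compounds below may be only part of what the source reports. "The series", "measured", "known", "first", "only" and "open" are said of these compounds alone.

In a toxicity assay on NIH3T3 cells (Mus musculus) for cytotoxicity, read by resazurin assay (on this read-out higher numbers stand for an effect only at larger amounts of compound and lower numbers for an effect already at smaller amounts), compound 1 (`Clc1ccc(NCc2cncn2Cc2ccc(-c3ccccc3)cc2)cc1-c1ccccc1`) gives > 1000 nM, and this value is a limit. Compound 2 (`CCC(=O)c1ccc(NCc2cncn2Cc2ccc(-c3ccccc3)cc2)cc1-c1ccccc1`) gives > 10000 nM, which is likewise a limit. Among the compounds with values here, compound 2 therefore stands only at a limit, and the one other value on this scale is also a limit.

Compound 3 (`c1ccc(-c2ccc(Cn3cncc3CNc3ccc(-c4nc5ccccc5o4)c(-c4ccccc4)c3)cc2)cc1`) follows from compound 2 by one change, (1,3-benzoxazol-2-yl in place of propanoyl on an aromatic carbon). In words, 1,3-benzoxazol-2-yl takes the place of propanoyl on an aromatic carbon, ortho to a phenyl group and para to a large group.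

Within the data shown here, only one measured step bears on this position, a step that the two limits leave unreadable from compound 1 to compound 2, where propanoyl replaced chloro on an aromatic carbon. That step has no readable size, so it offers no measure to carry over to the new group. With no size and no direction to lean on, no change beyond the usual scatter is expected in this assay. The expected step is a number no higher from compound 2 to compound 3 (the limit leaves the size open). In this assay compound 3 is estimated at 10000 nM, with an expected range from 3000 nM to 30000 nM.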

Compound 3, half-maximal effective concentration: > 10000 nM
Compound 3: only a limit was reported (the forecaster's own chance of this, stated with the estimate: 65%); the middle value lies on the limit itself.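

In this assay compound 3 gives > 10000 nM, which is a limit. Within the data shown here, with compound 1 and compound 2 also standing only at limits, no step among the three compounds can be read. The compounds shown leave open at what concentration any of them would show an effect in this assay, and whether chloro, propanoyl and 1,3-benzoxazol-2-yl differ at all there.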